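Swapping Cyclohexyl for 4-Fluorobenzyl on the Oxygen

The source may hold more compounds than are shown below. What is called first, only, known or untested is meant among the compounds shown, and "the series" means these compounds.

Compound 2 `CC(C(=O)NCc1ccc(C(F)(F)F)cc1OC1CCCCC1)c1ccc(NS(C)(=O)=O)c(F)c1` has been tested in an assay on CHO cells for antagonist activity at transient receptor potential cation channel subfamily V member 1 (Homo sapiens), read by FLIPR (on this read-out lower numbers stand for stronger inhibition and higher numbers for weaker inhibition), where compound 2 gives 0.7 nM. Within the data shown here, that is the lowest of the two numbers known so far. Among the measured compounds shown here, the only other measured compound, compound 1 `CC(C(=O)NCc1ccc(C(F)(F)F)cc1N1CCN(C2CCCCC2)CC1)c1ccc(NS(C)(=O)=O)c(F)c1`, gives 13.8 nM in this assay. For the measured compounds named here, the single measured change, cyclohexyloxy in place of 4-cyclohexylpiperazin-1-yl on an aromatic carbon, gave a 20-fold lower number from compound 1 to compound 2 (1.29 log units; beyond the scatter).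

Compound 3 `CC(C(=O)NCc1ccc(C(F)(F)F)cc1OCc1ccc(F)cc1)c1ccc(NS(C)(=O)=O)c(F)c1` has not yet been measured. It differs from compound 2 by 4-fluorobenzyl in place of cyclohexyl on an oxygen on an aromatic ring. Going by the values given here, no measured step concerns this exact change; the one step known involves a different group at the same side of the shared core, so it offers no direct guide, only a hint that changes there can move the number a great deal. Compound 3 is therefore expected to show a 2.9-fold higher number from compound 2 to compound 3 (0.46 log units; beyond the scatter), with wide margins. Compound 3 is expected to give about 2 nM in this assay, between 0.4 nM and 10 nM.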

Compound 3, inhibition constant: 0.5 nM
The estimate for compound 3 lay 4.0-fold (0.60 log units) above the measured number; the measured number falls inside the stated range.
By their numbers in this assay, from the lowest: compounds 3 and 2 (each within the scatter of the next); then compound 1.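

In this assay, a ring of carbon on the oxygen can be saturated or aromatic without a change beyond the scatter: 4-fluorobenzyl in place of cyclohexyl gives a 1.4-fold lower number from compound 2 to compound 3 (0.15 log units; within the scatter), so compound 2 and compound 3 cannot be told apart. The large step away from 4-cyclohexylpiperazin-1-yl is not limited to cyclohexyloxy, as (4-fluorobenzyl)oxy also gives a 28-fold lower number from compound 1 to compound 3 (1.44 log units; beyond the scatter). No available measurement explains why these two groups on the oxygen read alike.

The compounds shown leave open whether a plain benzyl group would read like 4-fluorobenzyl, which would show whether the fluorine matters here. They also leave open how the number would respond to a group on the oxygen without a ring, such as a butyl chain, or to one carrying an amine or a carboxylic acid.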